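The source may report more compounds than this note shows. Statements on the series, on what has been measured and on what is new or still open speak of the compounds shown alone.

- compound 1 `CC1CC/C(=N\Nc2ccc(F)cc2)c2ncc(C(=O)O)c(=O)n21` gives 1200 nM
- compound 2 `CC1CC/C(=N\Nc2ccc(O)cc2)c2ncc(C(=O)O)c(=O)n21` gives 1300 nM
- compound 3 `CC1CC/C(=N\Nc2ccc([N+](=O)[O-])cc2)c2ncc(C(=O)O)c(=O)n21` gives 8900 nM

Compound 3 at 8900 nM has the highest number of the three in a functional assay (mast cells) for inhibition, with Rattus norvegicus as the target (on this read-out higher numbers stand for an effect only at larger amounts of compound and lower numbers for an effect already at smaller amounts), and is the starting point here. Compound 4 `CCCCc1ccc(N/N=C2\CCC(C)n3c2ncc(C(=O)O)c3=O)cc1` differs from compound 3 by butyl in place of nitro on an aromatic carbon with butyl in place of nitro on an aromatic carbon. Going by the values given here, with a 7.4-fold higher number from compound 1 to compound 3 (0.87 log units; beyond the scatter) and a 6.8-fold higher number from compound 2 to compound 3 (0.84 log units; beyond the scatter) both modest and beyond the scatter, while a 1.1-fold higher number from compound 1 to compound 2 (0.03 log units; within the scatter) stays within it, a modest lowering is expected on leaving nitro, although no measured step involves butyl. The expected change is a 3.0-fold lower number from compound 3 to compound 4 (0.47 log units; beyond the scatter) on this read-out. For compound 4 the estimate is 3000 nM with an expected range of 800 nM to 11000 nM in this assay once measured.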

Compound 4, half-maximal effective concentration: 1700 nM
For compound 4 the middle estimate is 1.8-fold (0.25 log units) above the measured one; measured number inside the range.
By their numbers in this assay, from the lowest: compounds 1, 2 and 4 (each within the scatter of the next); then compound 3.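

Butyl at this aromatic carbon gives a 5.2-fold lower number from compound 3 to compound 4 (0.72 log units; beyond the scatter), so a purely carbon chain without hydrogen-bond acceptors does not share the higher number of nitro. Going by these compounds alone, the other two steps are a 1.3-fold higher number from compound 2 to compound 4 (0.12 log units; within the scatter) and a 1.4-fold higher number from compound 1 to compound 4 (0.15 log units; within the scatter), which places butyl level with hydroxy and fluoro and leaves nitro as the only one of the four groups that stands apart. Nothing measured here explains this difference.

From the compounds shown here alone, whether an amine, a methoxy group or a longer chain at this carbon would also stay level with these three remains open.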